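Replacing the Lactam on the Amide of Compound 3

The compounds below may be only part of what the source reports. "The series", "measured", "known", "first", "only" and "open" are said of these compounds alone.

Compound 1, `Cn1ccc2ccc(-c3cc(Nc4ccccc4S(N)(=O)=O)cc4nccnc34)cc21`: 265 nM
Compound 2, `CNS(=O)(=O)c1ccccc1Nc1cc(-c2ccc3ccn(C)c3c2)c2nccnc2c1`: 104 nM
Compound 3, `Cn1ccc2ccc(-c3cc(Nc4cnccc4C(=O)NC4CCNC(=O)C4)cc4nccnc34)cc21`: 69 nM

Of the compounds shown here, three sharing one core have been tested in an assay for inhibition of 6-phosphofructo-2-kinase/fructose-2,6-bisphosphatase 3 (Homo sapiens), read by ADP-Glo, with a stated time of 2 h; a lower number here means a stronger inhibitor, a higher number a weaker inhibitor. Compound 3 gives the lowest of the three numbers, though against compound 2 the gap is within the scatter, so no order between those two can be claimed; against compound 1 the gap is beyond the scatter.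

Compound 4, `CN1CCC(CNC(=O)c2ccncc2Nc2cc(-c3ccc4ccn(C)c4c3)c3nccnc3c2)C1`, is not yet measured. It differs from compound 3 in one place: (1-methylpyrrolidin-3-yl)methyl in place of 2-oxopiperidin-4-yl on an amide-type nitrogen. The group that leaves carries one hydrogen-bond donor and one acceptor; the group that enters carries no donor and one acceptor.

Going by the values given here, the only measured step, a 2.5-fold lower number from compound 1 to compound 2 (0.41 log units; beyond the scatter), concerns a sulfonamide nitrogen and does not touch the amide-type nitrogen changed here, so no measured step bears directly on this change. With nothing to point either way, compound 4 is expected to stay close to compound 3, with a step of a 1.2-fold higher number from compound 3 to compound 4 (0.09 log units; within the scatter) that need not exceed the scatter. Compound 4 is therefore estimated at 85 nM, within a range from 30 nM to 250 nM.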

Compound 4, half-maximal inhibitory concentration: 74 nM
Estimate against measurement, compound 4: 1.1-fold (0.06 log units) above; measured number inside the range.
By their numbers in this assay, from the lowest: compounds 3, 4 and 2 (each within the scatter of the next); then compound 1.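

In this assay, exchanging the group on this amide-type nitrogen gives a 1.1-fold higher number from compound 3 to compound 4 (0.03 log units; within the scatter), so compound 3 and compound 4 cannot be told apart. The 2-oxopiperidin-4-yl group carries a hydrogen-bond donor and a double bond outside aromatic rings, whereas (1-methylpyrrolidin-3-yl)methyl carries neither and has a five-membered rather than a six-membered ring, so in this one pair the number does not depend on those features. Why the two groups read alike cannot be said, as no supporting evidence bears on this result.

Open, going by these compounds, is whether a very different group on this nitrogen, such as a carboxylic acid or a longer alkyl chain, would also leave the number in place. Also open, on these data alone, is what the methyl of the entering group contributes, which the unmethylated pyrrolidin-3-ylmethyl group would show.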